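The source may hold more compounds than are shown below. What is called first, only, known or untested is meant among the compounds shown, and "the series" means these compounds.

Measured compounds:
- compound 1 `O=C(Oc1ccc(Br)cc1C(=O)Nc1ccc(C(F)(F)F)cc1)c1ccc(Br)cc1` gives 4200 nM in a functional assay on HepG2 cells (Homo sapiens), read by MTT assay, with a stated time of 72 h; a lower number here means a stronger inhibitor, a higher number a weaker inhibitor
- compound 2 `O=C(Oc1ccc(Cl)cc1C(=O)Nc1ccc(Cl)c(Cl)c1)c1ccc(Br)cc1` gives 2500 nM in this assay
- compound 3 `Cc1ccc(C(=O)Oc2ccc(Cl)cc2C(=O)Nc2ccc(Cl)c(Cl)c2)cc1` gives 2550 nM in this assay

Compound 3 has the second highest of the three numbers, but its distance to the others is small: compound 2 is nearest and compound 1 furthest, and both gaps lie within the scatter. For the measured compounds named here, the one single-point step in the set, a 1.0-fold higher number from compound 2 to compound 3 (0.01 log units; within the scatter), is the exchange of the benzoate substituent and lies within the scatter too.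

Compound 4 `Cc1ccc(C(=O)Oc2ccc(Cl)cc2C(=O)Nc2ccc(C(F)(F)F)cc2)cc1` differs from compound 3 by 4-(trifluoromethyl)phenyl in place of 3,4-dichlorophenyl on an amide-type nitrogen. Going by the values given here, no single-point step in the set bears on this change. Compound 1 carries the same 4-(trifluoromethyl)phenyl on the amide nitrogen, but it also differs from compound 2 at the core halogen, so the two values can only be read side by side: compound 1 at 4200 nM against compound 2 at 2500 nM, a gap within the scatter. No basis exists for expecting a step beyond the scatter in this assay; at most a modest shift toward a higher number is expected, a 1.4-fold higher number from compound 3 to compound 4 (0.14 log units; within the scatter). Compound 4 is therefore estimated at 3500 nM, with a range from 1500 nM to 8000 nM.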

Compound 4, half-maximal inhibitory concentration: 6900 nM
The estimate for compound 4 lay 2.0-fold (0.29 log units) below the measured number; the measured number falls inside the stated range.
By their numbers in this assay, from the lowest: compounds 2, 3, 1 and 4 (each within the scatter of the next, the first and the last beyond it).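

In this assay the substituent on the amide-type nitrogen is the one place in the series where a single change moves the number beyond the scatter: 4-(trifluoromethyl)phenyl in place of 3,4-dichlorophenyl gives a 2.7-fold higher number from compound 3 to compound 4 (0.43 log units; beyond the scatter) while methyl in place of bromo on an aromatic carbon gives only a 1.0-fold higher number from compound 2 to compound 3 (0.01 log units; within the scatter) and stays within it. The amide nitrogen substituent is therefore not interchangeable in this assay, and for this one pair 3,4-dichlorophenyl gives the lower number, although the finding rests on a single matched pair and on the shared core of compound 3 and compound 4 alone. The information available offers no measured basis for explaining this difference.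

From the compounds shown here alone, whether the step carries over to the bromo-substituted core stays open, since compound 1 and compound 2 differ in more than one place and that pair cannot be read as a single change. Also open, going by these compounds, is how the position responds to groups of another kind on the amide nitrogen, such as a phenyl ring bearing an amine or a carboxylic acid, or a longer alkyl chain in place of the aromatic ring.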